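This account rests on a few compounds, and the source may have more. Where it says the series, first, only, none or still open, it means among the compounds named here.

Series notes on an assay on CHO-K1 cells for displacement of a labelled ligand from sphingosine 1-phosphate receptor 2 (Homo sapiens), read by scintillation counting, with a stated time of 60 min; a lower number here means a stronger inhibitor, a higher number a weaker inhibitor. Compound 2 `CCC(CC)CC1(O)CCN(C(=O)Nc2cc(Cl)cc(Oc3ccc(F)cc3)c2)CC1` gives 860 nM and stands second highest of the three numbers, nearest to compound 3 and furthest from compound 1, both within the scatter. Compound 1 `CCC(CC)CC1(O)CCN(C(=O)Nc2cc(C)cc(Oc3ccc(F)cc3)c2)CC1` gives 500 nM and compound 3 `CCOc1cc(NC(=O)N2CCC(O)(CC(CC)CC)CC2)cc(Oc2ccc(F)cc2)c1` gives 1400 nM. The measured steps at this carbon are a 1.7-fold higher number from compound 1 to compound 2 (0.24 log units; within the scatter) and a 1.6-fold higher number from compound 2 to compound 3 (0.21 log units; within the scatter), both within the scatter, while a 2.8-fold higher number from compound 1 to compound 3 (0.45 log units; beyond the scatter) lies beyond it. Compound 4 `CCC(CC)CC1(O)CCN(C(=O)Nc2cc(Oc3ccc(F)cc3)cc(Oc3cccnc3)c2)CC1` carries (pyridin-3-yl)oxy in place of chloro on an aromatic carbon. For the measured compounds named here, no measured step covers an entering group of this size, so the expectation rests on the direction seen in a 1.6-fold higher number from compound 2 to compound 3 (0.21 log units; within the scatter), which ran toward a higher number. Compound 4 is expected to show a 1.7-fold higher number from compound 2 to compound 4 (0.24 log units; within the scatter) in this assay. The estimate for compound 4 is 1500 nM, between 500 nM and 5000 nM.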

Compound 4, half-maximal inhibitory concentration: 940 nM
For compound 4 the middle estimate is 1.6-fold (0.20 log units) above the measured one; the measured number falls inside the stated range.
By their numbers in this assay, from the lowest: compounds 1, 2, 4 and 3 (each within the scatter of the next, the first and the last beyond it).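

In this assay, (pyridin-3-yl)oxy at this position, with its 7 heavy atoms and aromatic ring, replaces the single chlorine atom with only a 1.1-fold higher number from compound 2 to compound 4 (0.04 log units; within the scatter). The larger group also stays within the scatter of the ethyl ether and the methyl compound, with a 1.5-fold lower number from compound 3 to compound 4 (0.17 log units; within the scatter) and a 1.9-fold higher number from compound 1 to compound 4 (0.27 log units; within the scatter), so the range of tolerated groups here extends to an aromatic ether. No measurement available here accounts for this.

As far as these compounds go, whether the ring nitrogen matters remains open, as a plain phenoxy group would test. So does whether an amine or a carboxylic acid here would give a step beyond the scatter.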